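Swapping the Acyl Aryl Group of Compound 3

The source may report more compounds than this note shows. Statements on the series, on what has been measured and on what is new or still open speak of the compounds shown alone.

Three compounds sharing one core were measured in an assay on THP-1 cells for antagonist activity at P2X purinoceptor 7 (Homo sapiens), read by ELISA, with a stated time of 30 min; a lower number here means a stronger inhibitor, a higher number a weaker inhibitor. Compound 1 `CNC(=O)c1cccc(S(=O)(=O)Oc2ccc(-c3cncn3C3CCN(C(=O)c4ccc(Cl)c(C(F)(F)F)c4)CC3)cc2)c1` gives 1.76 nM. Compound 2 `O=C(NC1CC1)c1cccc(S(=O)(=O)Oc2ccc(-c3cncn3C3CCN(C(=O)c4ccc(Cl)c(C(F)(F)F)c4)CC3)cc2)c1`, which carries cyclopropyl in place of methyl on an amide-type nitrogen, gives 58 nM, a shift of a 33-fold higher number from compound 1 to compound 2 (1.52 log units; beyond the scatter). Compound 3 `O=C(c1ccc(Cl)c(C(F)(F)F)c1)N1CCC(n2cncc2-c2ccc(OS(=O)(=O)c3cccc4cnccc34)cc2)CC1` gives 22 nM; it stands second highest of the three numbers, the nearer step to it being a 2.6-fold lower number from compound 2 to compound 3 (0.42 log units; beyond the scatter) and the further one a 13-fold higher number from compound 1 to compound 3 (1.10 log units; beyond the scatter).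

Compound 4 `CS(=O)(=O)c1ccc(C(=O)N2CCC(n3cncc3-c3ccc(OS(=O)(=O)c4cccc5cnccc45)cc3)CC2)cc1` differs from compound 3 in one place: 4-(methylsulfonyl)phenyl in place of 4-chloro-3-(trifluoromethyl)phenyl on a carbonyl carbon. Going by the values given here, every measured step so far changes the group on the sulfonyl sulfur or the substituent on the amide-type nitrogen; none touches the carbonyl carbon whose other neighbours are an amide-type nitrogen in a ring. Among the compounds with values here, there is therefore no measured step that bears directly on this change, and no basis in the data for a direction. The steps already seen, ranging from a 2.6-fold lower number from compound 2 to compound 3 (0.42 log units; beyond the scatter) to a 33-fold higher number from compound 1 to compound 2 (1.52 log units; beyond the scatter), only show that a single change in this series can move the number by a modest or a large amount. Compound 4 is expected to give about 60 nM, within a range of 10 nM to 350 nM, which would mean an estimated step of a 2.7-fold higher number from compound 3 to compound 4 (0.44 log units; beyond the scatter).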

Compound 4, half-maximal inhibitory concentration: 0.32 nM
The estimate for compound 4 lay 190-fold (2.27 log units) above the measured number; measured number outside the range, below it.
By their numbers in this assay, from the lowest: compound 4; then compound 1; then compound 3; then compound 2.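

In this assay, the carbonyl carbon whose other neighbours are an amide-type nitrogen in a ring turns out to be a position where a single change has a large effect: 4-(methylsulfonyl)phenyl in place of 4-chloro-3-(trifluoromethyl)phenyl gives a 69-fold lower number from compound 3 to compound 4 (1.84 log units; beyond the scatter) in the isoquinolin-5-yl sulfonyl series. The result also shows that the chlorine and trifluoromethyl substituents of the leaving group are not required for a low number at this position, since compound 4, with an entering group that has 2 hydrogen-bond acceptors where the leaving group has 0, reaches 0.32 nM in this series. No evidence is available that explains the size or direction of this step.

The compounds shown leave open whether the same swap would give a step of similar size with the 3-(methylcarbamoyl)phenyl or 3-(cyclopropylcarbamoyl)phenyl group on the sulfonyl sulfur, as only one sulfonyl group has been seen with both acyl groups. As far as these compounds go, it also remains open how a phenyl ring carrying a carboxylic acid, a nitrile or a primary sulfonamide would read on this carbonyl carbon.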